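Changing the Aromatic Group on the Ring Amine Nitrogen

This account rests on a few compounds, and the source may have more. Where it says the series, first, only, none or still open, it means among the compounds named here.

Measured compounds:
Compound 1, `CCCn1c(=O)[nH]c2nc(-c3ccc(S(=O)(=O)N4CCN(Cc5ccc(Br)cc5)CC4)cc3)[nH]c2c1=O`: 0.153 nM
Compound 2, `CCCn1c(=O)[nH]c2nc(-c3ccc(S(=O)(=O)N4CCN(c5ccccc5Cl)CC4)cc3)[nH]c2c1=O`: 0.403 nM
Compound 3, `CCCn1c(=O)[nH]c2nc(-c3ccc(S(=O)(=O)N4CCN(C(C)c5ccccc5)CC4)cc3)[nH]c2c1=O`: 8.34 nM

All three share a core and differ only in the group on an amine nitrogen in a ring. In an assay on CHO cells for displacement of a labelled ligand from adenosine receptor A2b (Homo sapiens), read by scintillation counting, with a stated time of 75 min, in the presence of a further agent that is not named here (a lower number here means a stronger inhibitor, a higher number a weaker inhibitor), compound 2 holds the second highest number of the three: its nearest neighbour is compound 1, with a 2.6-fold higher number from compound 1 to compound 2 (0.42 log units; beyond the scatter), and its furthest is compound 3, with a 21-fold higher number from compound 2 to compound 3 (1.32 log units; beyond the scatter).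

Compound 4, `CCCn1c(=O)[nH]c2nc(-c3ccc(S(=O)(=O)N4CCN(c5ccc(C)cc5)CC4)cc3)[nH]c2c1=O`, is not yet measured. Its change from compound 2 is 4-methylphenyl in place of 2-chlorophenyl on an amine nitrogen in a ring. Two kinds of step are known: the modest one, a 2.6-fold higher number from compound 1 to compound 2 (0.42 log units; beyond the scatter), where a 4-bromobenzyl gave way to an aromatic ring joined directly to the nitrogen, and the large ones, a 55-fold higher number from compound 1 to compound 3 (1.74 log units; beyond the scatter) and a 21-fold higher number from compound 2 to compound 3 (1.32 log units; beyond the scatter), where a 1-phenylethyl entered. Going by the values given here, no measured step exchanges one directly attached aromatic ring for another, so the expectation rests on the smaller of these. A step of no more than modest size is expected, most likely within the scatter: a 1.5-fold higher number from compound 2 to compound 4 (0.17 log units; within the scatter). Compound 4 is therefore estimated at 0.6 nM, with a range of 0.2 nM to 2 nM.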

Compound 4, inhibition constant: 0.706 nM
For compound 4 the middle estimate is 1.2-fold (0.07 log units) below the measured one; low and high end bracket the measured number.
By their numbers in this assay, from the lowest: compound 1; then compounds 2 and 4 (each within the scatter of the next); then compound 3.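

Going by these compounds alone, exchanging one directly attached aromatic ring for another is a step the earlier compounds did not include, and in this assay it leaves the two groups indistinguishable (a 1.8-fold higher number from compound 2 to compound 4 (0.24 log units; within the scatter)), even though a chlorine-bearing ring gives way to a methyl-bearing one. The low numbers at this ring nitrogen are therefore not tied to the 2-chlorophenyl group alone, and the 1-phenylethyl group remains well apart from a second directly attached ring (a 12-fold lower number from compound 3 to compound 4 (1.07 log units; beyond the scatter)). The 4-bromobenzyl group still gives a lower number than this new ring, although the gap is only modest (a 4.6-fold higher number from compound 1 to compound 4 (0.66 log units; beyond the scatter)).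

As far as these compounds go, it remains open whether a phenyl ring carrying an amine or a carboxylic acid, or a longer chain on the same nitrogen, would keep the numbers this low. Nothing measured here explains these differences.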